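The compounds below may be only part of what the source reports. "The series", "measured", "known", "first", "only" and "open" are said of these compounds alone.

Measured compounds in a functional assay on MCF7 cells (Homo sapiens) for inhibition, read by MTT assay, with a stated time of 48 h, tested at 30 ug/mL; on this read-out lower numbers stand for less inhibition of growth and higher numbers for more inhibition of growth at the one concentration tested:
compound 1 `O=c1cc(-c2ccccc2)oc2cc(N3COc4c(Cl)cc(Cl)cc4C3)ccc12` gives 34.6%
compound 2 `O=c1cc(-c2ccccc2)oc2cc(N3COc4c(Br)cccc4C3)ccc12` gives 7.89%
compound 3 `O=c1cc(-c2ccccc2)oc2cc(N3COc4c(Br)cc(Br)cc4C3)ccc12` gives 11.1%

Compound 2 stands lowest of the three numbers in this assay; compound 3 lies nearest to it, within the scatter, while compound 1 lies furthest, beyond the scatter.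

Compound 4 `O=c1cc(-c2ccccc2)oc2cc(N3COc4ccccc4C3)ccc12` is not yet measured. From compound 2 it differs by hydrogen in place of bromo on an aromatic carbon. Among the measured compounds shown here, only one measured step touches this part of the molecule: a number 3.2 percentage points higher from compound 2 to compound 3 (within the scatter), a change that did not move the read-out beyond the scatter. For the measured compounds named here, compound 1, which carries chloro rather than bromo, does stand higher than compound 2, but no single-place step links it to compound 2 or compound 4, so its number bears only indirectly on the question. On the evidence of the step from compound 2 to compound 3, removing the bromo is expected to give a step of a number 1.1 percentage points higher from compound 2 to compound 4 (within the scatter) in this assay, with no direction beyond the scatter. Compound 4 is therefore estimated at 9%, in the range 0% to 22%.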

Compound 4, percent growth inhibition at one concentration: 12.7%
Compound 4: middle estimate off by 3.7 percentage points, on the low side; the range from low to high includes it.
By their numbers in this assay, from the lowest: compounds 2, 3 and 4 (each within the scatter of the next); then compound 1.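

In this assay, among the compounds shown here, hydrogen in place of bromo on this aromatic carbon, ortho to a fused ring and meta to a fused ring, gives a number 4.8 percentage points higher from compound 2 to compound 4 (within the scatter), the first step at this carbon itself. The earlier step, a number 3.2 percentage points higher from compound 2 to compound 3 (within the scatter), added a bromo on another aromatic carbon, so neither adding that bromo nor removing this one has moved the read-out beyond the scatter. No measured evidence on the cause of this outcome is available.

Still open, as far as these compounds go, is whether a single chloro, a methoxy or an amine on this carbon would move the read-out beyond the scatter. For the compounds shown here, also open is what sets compound 1 at 34.6% apart, since no single-place step links it to any other compound.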